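Benzodioxin on the carbonyl carbon in the methyl series

This account rests on a few compounds, and the source may have more. Where it says the series, first, only, none or still open, it means among the compounds named here.

Compound 3 (`Cc1ccc(-c2nc3ccccc3[nH]2)cc1NC(=S)NC(=O)c1ccccc1`) is the methyl analogue of compound 1 (`O=C(NC(=S)Nc1cccc(-c2nc3ccccc3[nH]2)c1)c1ccccc1`), with methyl in place of hydrogen on an aromatic carbon. In a functional assay on MDA-MB-231 cells (Homo sapiens) for inhibition, read by colorimetric assay and crystal violet staining, with a stated time of 72 h (a higher number here means a weaker inhibitor, a lower number a stronger inhibitor), compound 3 gives > 10000 nM, which is a limit of the assay and not a number. Compound 1 likewise sits at a limit in this assay, at > 10000 nM. The step that the two limits leave unreadable from compound 1 to compound 3 therefore cannot be read. Going by the values given here, compound 2 (`O=C(NC(=S)Nc1cccc(-c2nc3ccccc3[nH]2)c1)c1ccc2c(c1)OCCO2`) carries 2,3-dihydro-1,4-benzodioxin-6-yl in place of phenyl on the carbonyl carbon and gives 500 nM in this assay; the step of an at least 20-fold lower number from compound 1 to compound 2 (1.30 log units; beyond the scatter) is the one measured step that bears on the change now in view, and it is large. Compound 4 (`Cc1ccc(-c2nc3ccccc3[nH]2)cc1NC(=S)NC(=O)c1ccc2c(c1)OCCO2`) differs from compound 3 by 2,3-dihydro-1,4-benzodioxin-6-yl in place of phenyl on a carbonyl carbon. Among the compounds with values here, since compound 3 stands only at the limit of > 10000 nM in this assay, at which 2 of the 3 values shown sit, the size of the step cannot be anchored on both sides, but the change is the same as the one between compound 1 and compound 2, so a large drop in this assay is expected. The estimate for compound 4 is 1000 nM, between 300 nM and 8000 nM. This corresponds to an expected step of an at least 10-fold lower number from compound 3 to compound 4 (1.00 log units; beyond the scatter).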

Compound 4, half-maximal inhibitory concentration: 500 nM
Beside the measured number, compound 4's estimate is 2.0-fold (0.30 log units) above it; the measured number falls inside the stated range.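

In this assay the change from phenyl to 2,3-dihydro-1,4-benzodioxin-6-yl on the carbonyl carbon now also appears on the methyl-bearing core, with an at least 20-fold lower number from compound 3 to compound 4 (1.30 log units; beyond the scatter), so it no longer rests on a single pair: the same change on two cores in this assay, an at least 20-fold lower number (1.30 log units; beyond the scatter) from compound 1 to compound 2 and an at least 20-fold lower number (1.30 log units; beyond the scatter) from compound 3 to compound 4; the limit leaves it open whether they differ

Going by these compounds alone, with this group in place, the methyl in place of hydrogen on an aromatic carbon can be read for the first time, and it gives no change at the digits printed from compound 2 to compound 4 (within the scatter); the phenyl pair could not show this, as both of its members stand at a limit of the assay and not at a number. The full size of both benzodioxin steps therefore stays unknown, and the phenyl compounds give only a floor for it: the limit of > 10000 nM in this assay, at which 2 of the 4 values shown sit.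

The compounds shown leave open whether a phenyl carrying a single methoxy group on the carbonyl carbon would give a similar step, or whether the complete 2,3-dihydro-1,4-benzodioxin-6-yl group is needed. They also leave open whether an ethyl group or a chlorine atom in place of the methyl would stay level with compound 4.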